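The source may report more compounds than this note shows. Statements on the series, on what has been measured and on what is new or still open speak of the compounds shown alone.

The measured compounds:

Compound 1, `CN(C[C@@H]1CCCc2cc(S(=O)(=O)c3cccc(F)c3)ccc21)S(N)(=O)=O`: 3.98 nM
Compound 2, `CN(C)S(=O)(=O)NC[C@@H]1CCCc2cc(S(=O)(=O)c3cccc(F)c3)ccc21`: 2 nM
Compound 3, `O=C1CN(C[C@@H]2CCCc3cc(S(=O)(=O)c4cccc(F)c4)ccc32)CCN1`: 6.31 nM

All three share one core and differ only in the group on a saturated chain carbon bound to a saturated ring carbon. In an assay on isolated protein for displacement of a labelled ligand from 5-hydroxytryptamine receptor 6 (Homo sapiens) (on this read-out lower numbers stand for stronger inhibition and higher numbers for weaker inhibition), compound 3 gives the highest of the three numbers. The step of a 1.6-fold higher number from compound 1 to compound 3 (0.20 log units; within the scatter) is small, whereas a 3.2-fold higher number from compound 2 to compound 3 (0.50 log units; beyond the scatter) is larger and counts as a modest loss. Between the two sulfamoyl-bearing compounds the step is a 2.0-fold lower number from compound 1 to compound 2 (0.30 log units; within the scatter).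

Compound 4, `O=S(=O)(c1cccc(F)c1)c1ccc2c(c1)CCC[C@H]2CNCCO`, has not been measured in this assay. It differs from compound 3 in one place: (2-hydroxyethyl)amino in place of 3-oxopiperazin-1-yl on a saturated chain carbon bound to a saturated ring carbon. For the measured compounds named here, no measured step exchanges a ring for an open chain at this position, so the bearing of the known steps is indirect: the exchanges of one group for another at the same place gave a 1.6-fold higher number from compound 1 to compound 3 (0.20 log units; within the scatter) and a 3.2-fold higher number from compound 2 to compound 3 (0.50 log units; beyond the scatter), neither of them large. On that basis a step of similar size is expected at most, with the direction uncertain; a slightly higher number is the estimate, a 1.3-fold higher number from compound 3 to compound 4 (0.10 log units; within the scatter). Compound 4 is therefore expected near 8 nM, within a range from 3 nM to 25 nM.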

Compound 4, inhibition constant: 0.126 nM
For compound 4 the middle estimate is 63-fold (1.80 log units) above the measured one; the measured number lies below the stated range.
By their numbers in this assay, from the lowest: compound 4; then compounds 2, 1 and 3 (each within the scatter of the next, the first and the last beyond it).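

In this assay, the place on a saturated chain carbon bound to a saturated ring carbon turns out to be far more sensitive than the first three compounds suggested, since their steps stayed small or modest. Putting the open-chain (2-hydroxyethyl)amino in place of the ring 3-oxopiperazin-1-yl gives a 50-fold lower number from compound 3 to compound 4 (1.70 log units; beyond the scatter) and the same group in place of methyl(sulfamoyl)amino gives a 32-fold lower number from compound 1 to compound 4 (1.50 log units; beyond the scatter) while 2-hydroxyethyl in place of dimethylsulfamoyl on the amine nitrogen gives a 16-fold lower number from compound 2 to compound 4 (1.20 log units; beyond the scatter) so the gain holds against all three earlier groups. Compound 4 is thus the strongest of the four, and this place can clearly take a small group with no ring and no sulfamoyl unit without any loss.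

Nothing available explains this gain. The compounds shown leave open which part of the (2-hydroxyethyl)amino group carries it: a plain ethylamino group, a 2-methoxyethylamino group or a longer 3-hydroxypropylamino chain would tell the hydroxyl, its hydrogen and the chain length apart.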